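A few compounds are considered here, and "the series" means these few. Any claim that something is new, unique, unknown or untested is made for them only; others in the source may bear on it.

Measured so far in a functional assay on SK-OV-3 cells (Homo sapiens) for inhibition, read by sulforhodamine B assay, with a stated time of 48 h; a lower number here means that less compound is tolerated, a higher number that more compound is tolerated:
compound 1 `COc1ccc(-c2cc(/C=C/C(=O)c3ccc(N)cc3)[nH]n2)cc1` gives 63600 nM
compound 2 `COc1ccc(-c2cc(/C=C/C(=O)c3ccc(N)cc3)[nH]n2)cc1OC` gives 41300 nM
compound 3 `COc1cc(C(=O)/C=C/c2cc(-c3cc(OC)c(OC)c(OC)c3)n[nH]2)cc(OC)c1OC` gives 33400 nM

All three values lie within the scatter of one another, so none of them can be called stronger or weaker than the others. Compound 4 `COc1ccc(-c2cc(/C=C/C(=O)c3cc(OC)c(OC)c(OC)c3)[nH]n2)cc1OC` has not yet been measured in this assay. It arises from compound 3 by a single change: hydrogen in place of methoxy on an aromatic carbon. The same kind of change leads from compound 2 to compound 1: hydrogen in place of methoxy on an aromatic carbon, and that step measured a 1.5-fold higher number from compound 2 to compound 1 (0.19 log units; within the scatter). The two places are not identical, though: in compound 3 the aromatic carbon is also meta to a methoxy group, which is not the case in compound 2. The difference between the core of compound 3 and the core of compound 2 is not broken down here. Because the step of a 1.5-fold higher number from compound 2 to compound 1 (0.19 log units; within the scatter) stayed within the scatter, for compound 4 a similarly small step is expected, a 1.3-fold higher number from compound 3 to compound 4 (0.13 log units; within the scatter), with wide room either way since it rests on a single precedent on a different core. Compound 4 is therefore estimated at 45000 nM, most likely between 20000 nM and 100000 nM.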

Compound 4, concentration lethal to 50% of the cells: 45500 nM
Estimate against measurement, compound 4: 1.0-fold (0.00 log units) below; the measured number falls inside the stated range.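

In this assay, putting hydrogen in place of a methoxy group on an aromatic carbon gives a 1.4-fold higher number from compound 3 to compound 4 (0.13 log units; within the scatter). Set beside the earlier case, the change reads alike on the two cores: the same change on two cores in this assay, a 1.5-fold higher number (0.19 log units; within the scatter) from compound 2 to compound 1 and a 1.4-fold higher number (0.13 log units; within the scatter) from compound 3 to compound 4, 1.1-fold (0.05 log units) apart, within the scatter of two such steps. This shows that, on both of these cores, the change left the number within the usual scatter, but it does not show a real effect that carries from one core to the other, since neither step can be told apart from no change at all, and two cores say nothing about any others.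

The compounds shown have only hydrogen in place of methoxy, so it remains open whether a hydroxyl group, a carboxylic acid or a longer chain such as ethoxy would give a step beyond the scatter. Going by these compounds, it also remains open whether the same change would read alike in other cell types.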